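The source may report more compounds than this note shows. Statements on the series, on what has been measured and on what is new or still open speak of the compounds shown alone.

Compound 2 `Cc1cccc(NC(=O)CN2CCC(c3cccc(C#N)n3)CC2)c1` and compound 1 `COc1ccccc1C1CCN(CC(=O)Nc2cccc(C)c2)CC1` share one core and differ only in the aromatic group on a saturated ring carbon. In a functional assay on HEK293 cells for agonist activity at D(4) dopamine receptor (Homo sapiens), read by FLIPR (a higher number here means a larger maximal response, a lower number a smaller maximal response), compound 1 gives 43%, while compound 2 gives 42%, the lower of the two numbers, although the step of a number 1 percentage points lower from compound 1 to compound 2 (within the scatter) lies within the scatter. Compound 3 `Cc1cccc(NC(=O)CN2CCC(c3ccccc3F)CC2)c1` alters that same position once more: 2-fluorophenyl in place of 6-cyanopyridin-2-yl on a saturated ring carbon. Among the measured compounds shown here, the only measured exchange at this carbon stayed within the scatter, so no step beyond the scatter is expected here. The step from compound 2 to compound 3 is expected to be a number 1 percentage points higher from compound 2 to compound 3 (within the scatter). Compound 3 is estimated at 43%, with a range from 28% to 58%.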

Compound 3, largest response reached (reported as efficacy), in percent of the reference or control that the assay uses: 57%
The estimate for compound 3 lay 14 percentage points below the measured number, within the range that was stated.
By their numbers in this assay, from the lowest: compounds 2 and 1 (each within the scatter of the next); then compound 3.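

In this assay the group on this saturated ring carbon turns out to matter: 2-fluorophenyl in place of 6-cyanopyridin-2-yl gives a number 15 percentage points higher from compound 2 to compound 3 (beyond the scatter) and fluoro in place of methoxy on an aromatic carbon gives a number 14 percentage points higher from compound 1 to compound 3 (beyond the scatter) as a second modest rise. The earlier exchange at this carbon showed no such separation, whereas 2-fluorophenyl now stands clear of both other groups. No measurement available here explains the rise. Open, going by these compounds, is how a plain phenyl, a chlorophenyl or an aminophenyl would compare on this carbon.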